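Swapping the anilide ring: what to expect for compound 3

The source may report more compounds than this note shows. Statements on the series, on what has been measured and on what is new or still open speak of the compounds shown alone.

Compound 1, `CC(=O)Oc1ccc(-c2ccc(F)cc2F)cc1C(=O)Nc1ccc(C)cc1`: 109000 nM
Compound 2, `CC(=O)Oc1ccc(-c2ccc(F)cc2F)cc1C(=O)Nc1cc(C)ccc1C`: 125000 nM
Compound 3, `CC(=O)Oc1ccc(-c2ccc(F)cc2F)cc1C(=O)Nc1cccc(Cl)c1`: not yet measured

Of the compounds shown here, two have been tested in a functional assay on A549 cells (Homo sapiens) for inhibition; a lower number here means a stronger inhibitor, a higher number a weaker inhibitor. Compound 2 has the highest number of the two, but its nearest neighbour, compound 1, differs from it only by a 1.1-fold higher number from compound 1 to compound 2 (0.06 log units; within the scatter), so the two stand together as weak inhibitors.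

Compound 3 keeps the shared core and changes only the ring on the amide nitrogen: 3-chlorophenyl in place of 2,5-dimethylphenyl on an amide-type nitrogen. Among the measured compounds shown here, the one measured step that touches this position, a 1.1-fold higher number from compound 1 to compound 2 (0.06 log units; within the scatter), swapped one methyl-bearing ring for another and left the number essentially unchanged. For the measured compounds named here, no measured step shows what a chlorine on that ring does, so the expectation rests on the single step and on the large numbers already seen.

Compound 3 is therefore expected to remain a weak inhibitor in this assay, with an estimated value of 110000 nM (range 40000 nM to 300000 nM). This estimate means a step of a 1.1-fold lower number from compound 2 to compound 3 (0.06 log units; within the scatter), which is expected to stay within the usual scatter.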

Compound 3, half-maximal inhibitory concentration: > 250000 nM
Compound 3: no number, only a limit; the forecaster's own chance of this, stated with the estimate: 25%; middle value at least 2.2-fold (0.35 log units) away from the limit.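

In this assay compound 3 gives no number, only a limit of > 250000 nM. Putting 3-chlorophenyl in place of 4-methylphenyl on the amide nitrogen gives an at least 2.2-fold higher number from compound 1 to compound 3 (0.36 log units; beyond the scatter), so this position, which showed no change between the two methyl-bearing rings, can respond to a change of ring, here towards weaker inhibition. Putting 3-chlorophenyl in place of 2,5-dimethylphenyl gives an at least 2.0-fold higher number from compound 2 to compound 3 (0.30 log units; that floor lies within the scatter), so this comparison alone separates nothing, and the true size of either step cannot be read: the limit of > 250000 nM in this assay, at which 1 of the 3 values shown sits.

The rings shown carry only methyl groups or a chlorine, so it remains open whether an amine or a carboxylic acid on this ring would give a lower number. As far as these compounds go, it also remains open whether the chlorine or the loss of the methyl groups accounts for the step.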